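Chain length and aryl substitution in a carbamoyl-oxazolone series

A few compounds are considered here, and "the series" means these few. Any claim that something is new, unique, unknown or untested is made for them only; others in the source may bear on it.

Measured so far in an assay on HEK293 cells for inhibition of acid ceramidase (Homo sapiens), with a stated time of 10 min; a lower number here means a stronger inhibitor, a higher number a weaker inhibitor:
compound 1 `O=C(NCCCCc1ccccc1)n1c(=O)oc2ccccc21`, 64 nM
compound 2 `O=C(NCCCc1ccccc1)n1c(=O)oc2ccccc21`, 55 nM
compound 3 `COc1ccc(CCCCNC(=O)n2c(=O)oc3ccccc32)cc1`, 63 nM

Compound 3 stands second highest of the three, with compound 1 and compound 2 both within the scatter of it. Compound 4 `O=C(NCCCCCc1ccccc1)n1c(=O)oc2ccccc21` differs from compound 3 by benzyl in place of 4-methoxyphenyl on a saturated chain carbon, four bonds along the chain from an amide-type nitrogen. Among the compounds with values here, two measured steps bear on this: the chain shortening a 1.2-fold lower number from compound 1 to compound 2 (0.07 log units; within the scatter) and the methoxy addition a 1.0-fold lower number from compound 1 to compound 3 (0.01 log units; within the scatter), both within the scatter. Neither changing the chain length nor removing the methoxy has moved this assay beyond the scatter, so no step beyond the scatter is expected here. Compound 4 is therefore expected at 60 nM, with a range of 30 nM to 120 nM. The estimated step of a 1.1-fold lower number from compound 3 to compound 4 (0.02 log units; within the scatter) is expected to stay within the scatter.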

Compound 4, half-maximal inhibitory concentration: 54 nM
Beside the measured number, compound 4's estimate is 1.1-fold (0.05 log units) above it; measured number inside the range.
By their numbers in this assay, from the lowest: compounds 4, 2, 3 and 1 (each within the scatter of the next).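

In this assay the longer chain of compound 4 is not told apart from the shorter chains, with a 1.0-fold lower number from compound 2 to compound 4 (0.01 log units; within the scatter) and a 1.2-fold lower number from compound 1 to compound 4 (0.07 log units; within the scatter) both inside the scatter. The step of a 1.2-fold lower number from compound 3 to compound 4 (0.07 log units; within the scatter) also stays inside the scatter with chain length and the methoxy changing together, so neither change stands out at this position. No evidence bears on why these numbers stay so close.

Open, as far as these compounds go, are a still longer chain and an amine or a carboxylic acid in place of the methoxy on the aromatic ring. Whether any of these moves the number beyond the scatter cannot be told from these compounds.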